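Cyano in Place of Methyl on an Aromatic Carbon

The source may hold more compounds than are shown below. What is called first, only, known or untested is meant among the compounds shown, and "the series" means these compounds.

Of the compounds shown here, two with a shared core have been measured in a functional assay on KG-1 cells (Homo sapiens) for cytotoxicity, read by luminescence and CellTiter-Glo, with a stated time of 3 days; a higher number here means a weaker inhibitor, a lower number a stronger inhibitor. Compound 1 `N#Cc1cc(Cl)ccc1NC(=O)c1ccc2cccnc2c1O` gives 3540 nM, and compound 2 `Cc1cc(C#N)ccc1NC(=O)c1ccc2cccnc2c1O` gives 3240 nM. These two values lie within the scatter of each other, so compound 2 stands level with compound 1.

Compound 3 `N#Cc1ccc(NC(=O)c2ccc3cccnc3c2O)c(C#N)c1` has cyano in place of methyl on an aromatic carbon, ortho to a large group and meta to a cyano group: cyano in place of methyl on an aromatic carbon. Among the measured compounds shown here, no measured pair isolates this change, so any expectation rests on thin evidence. Compound 1 also carries a cyano group and reads 3540 nM, which gives no reason to expect a shift in either direction. The expected change in this assay is a 1.0-fold lower number from compound 2 to compound 3 (0.01 log units; within the scatter), which would be no step beyond the scatter. For compound 3 the estimated value is 3200 nM, with an expected range from 1300 nM to 8000 nM.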

Compound 3, half-maximal inhibitory concentration: 3770 nM
Estimate against measurement, compound 3: 1.2-fold (0.07 log units) below; the range from low to high includes it.
By their numbers in this assay, from the lowest: compounds 2, 1 and 3 (each within the scatter of the next).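

Among the compounds shown here, this result gives the first measured pair that isolates the change at this position, the aromatic carbon ortho to a large group and meta to a cyano group. In this assay, cyano in place of methyl on an aromatic carbon gives a 1.2-fold higher number from compound 2 to compound 3 (0.07 log units; within the scatter), so the read-out does not separate these two groups at this position. Cyano in place of chloro on an aromatic carbon gives a 1.1-fold higher number from compound 1 to compound 3 (0.03 log units; within the scatter), so this second single change likewise leaves the number level, and nothing shown here offers an explanation for either reading.

The compounds shown carry only methyl, chloro and cyano in these places, so they cannot tell whether an amine or a carboxylic acid on this aromatic carbon would read level too. A longer chain there also remains an open case.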